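The source may report more compounds than this note shows. Statements on the series, on what has been measured and on what is new or still open speak of the compounds shown alone.

Measured in a functional assay on PBMC cells (Homo sapiens) for inhibition, read by HTRF, with stated times of 15 min and 24 h; on this read-out higher numbers stand for weaker inhibition and lower numbers for stronger inhibition:
- Compound 1 `O=C(Nc1ccc2c(c1)B(O)OC2)c1ccccc1C(F)(F)F`: 4400 nM
- Compound 2 `O=C(Nc1ccc2c(c1)B(O)OC2)c1ccc(C(F)(F)F)cc1`: > 100000 nM, a limit of the assay
- Compound 3 `O=C(Nc1ccc2c(c1)B(O)OC2)c1ccc(C(F)(F)F)cc1F`: > 100000 nM, a limit of the assay

Compound 3 has no number, only a limit, > 100000 nM. Compound 2 is in the same position, and the two together make up (the limit of > 100000 nM in this assay, at which 2 of the 3 values shown sit).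

Compound 4 `O=C(Nc1ccc2c(c1)B(O)OC2)c1ccc(C(F)(F)F)cc1C(F)(F)F` carries trifluoromethyl in place of fluoro on an aromatic carbon, the change from compound 3 being (trifluoromethyl in place of fluoro on an aromatic carbon). Going by the values given here, the only measured step in one place, a step that the two limits leave unreadable from compound 2 to compound 3, gives no size to build on, so it sets no expectation for this change.

The closer guide is compound 1, which gives 4400 nM and also has a trifluoromethyl group ortho to a large group. Compound 1 lacks the second trifluoromethyl group that compound 4 keeps from compound 3, however, so the guide is only partial. A modest shift toward stronger inhibition is therefore expected in this assay, although compound 4 may well remain at the limit.

The expected step is an at least 1.6-fold lower number from compound 3 to compound 4 (0.22 log units; that floor lies within the scatter). For compound 4 the estimated value is 60000 nM, with an expected range from 12000 nM to 100000 nM.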

Compound 4, half-maximal inhibitory concentration: 8300 nM
Estimate against measurement, compound 4: 7.2-fold (0.86 log units) above; measured number outside the range, below it.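

Trifluoromethyl ortho to a large group gives a readable value where fluoro did not: in this assay, the exchange for fluoro gives an at least 12-fold lower number from compound 3 to compound 4 (1.08 log units; beyond the scatter), and the same group in place of hydrogen gives an at least 12-fold lower number from compound 2 to compound 4 (1.08 log units; beyond the scatter). The trifluoromethyl group meta to this one has little readable weight once the ortho group is present, since adding it gives a 1.9-fold higher number from compound 1 to compound 4 (0.28 log units; within the scatter), which leaves the two compounds indistinguishable in this assay. Among the four compounds, a number appears only with trifluoromethyl at the ortho place, as in compound 1 and compound 4, whereas compound 2 and compound 3 stand only at a limit of the assay: the limit of > 100000 nM in this assay, at which 2 of the 4 values shown sit.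

Going by these compounds, those limits mean that both large steps are floors, so the true size of the gain from trifluoromethyl at this place remains unknown. On these data alone, it also remains open whether this place needs trifluoromethyl itself or would accept another group, such as methyl, chloro, methoxy or nitrile, and whether a group other than trifluoromethyl at the meta place would keep the value of compound 4.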